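Adding an Amino Group to the Pyridyl Analogue

The source may hold more compounds than are shown below. What is called first, only, known or untested is meant among the compounds shown, and "the series" means these compounds.

Compound 1 `Cc1ncc([N+](=O)[O-])n1CCSc1nnc(-c2ccccc2)o1` is the parent here; in a functional assay on HepG2 cells (Homo sapiens) for cytotoxicity, read by MTT assay, with a stated time of 48 h (on this read-out lower numbers stand for stronger inhibition and higher numbers for weaker inhibition), compound 1 gives 17500 nM. Compound 2 `Cc1ncc([N+](=O)[O-])n1CCSc1nnc(-c2ccc(N)cc2)o1` differs by amino in place of hydrogen on an aromatic carbon and gives 6700 nM, so that a 2.6-fold lower number from compound 1 to compound 2 (0.42 log units; beyond the scatter). Compound 3 `Cc1ncc([N+](=O)[O-])n1CCSc1nnc(-c2cccnc2)o1` carries a different ring on the shared core, (pyridin-3-yl in place of phenyl on an aromatic carbon), and compound 3 gives 9600 nM, with a 1.8-fold lower number from compound 1 to compound 3 (0.26 log units; within the scatter). Between the two, a 1.4-fold higher number from compound 2 to compound 3 (0.16 log units; within the scatter).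

Compound 4 `Cc1ncc([N+](=O)[O-])n1CCSc1nnc(-c2cnccc2N)o1` differs from compound 3 by amino in place of hydrogen on an aromatic carbon. This is the same kind of change as from compound 1 to compound 2, but not the same: there the amino sat on a six-membered aromatic ring of carbon only, para to a large group; here it sits on a six-membered aromatic ring with 1 nitrogen, ortho to a large group, opposite the ring nitrogen. Compound 4 is expected to show a 1.7-fold lower number from compound 3 to compound 4 (0.24 log units; within the scatter). That expectation rests on the earlier step of a 2.6-fold lower number from compound 1 to compound 2 (0.42 log units; beyond the scatter), discounted for the changed surroundings. Compound 4 is estimated at 5500 nM, between 2500 nM and 12000 nM.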

Compound 4, half-maximal inhibitory concentration: 8400 nM
Estimate against measurement, compound 4: 1.5-fold (0.18 log units) below; measured number inside the range.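

In this assay, putting amino in place of hydrogen on the pyridin-3-yl compound gives a 1.1-fold lower number from compound 3 to compound 4 (0.06 log units; within the scatter), and the wider comparisons read a 1.3-fold higher number from compound 2 to compound 4 (0.10 log units; within the scatter) and a 2.1-fold lower number from compound 1 to compound 4 (0.32 log units; beyond the scatter). Set beside the earlier amino step, this result cannot be firmly separated from it: the same change on two cores in this assay, a 2.6-fold lower number (0.42 log units; beyond the scatter) from compound 1 to compound 2 and a 1.1-fold lower number (0.06 log units; within the scatter) from compound 3 to compound 4, 2.3-fold (0.36 log units) apart, within the scatter of two such steps. So the two cores show no firm difference in how they respond, but this does not prove that the change carries across, as only the earlier of the two amino steps lies beyond the scatter.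

Still open, on these data alone, is how a methyl or hydroxyl group would read in the same place on the ring. Also open, as far as these compounds go, is whether a dimethylamino group would follow the amino group on either core.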